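The source may report more compounds than this note shows. Statements on the series, on what has been measured and on what is new or still open speak of the compounds shown alone.

Compound 3 `COc1ccc(-c2cnc3nc(N)nc(N4CCN(C(=O)Nc5ccccc5)CC4)c3n2)cc1OC` gives 3.4 nM in a functional assay on cells (T-cell, Homo sapiens) for inhibition (on this read-out higher numbers stand for weaker inhibition and lower numbers for stronger inhibition), the lowest number of the three measured. Compound 1 `COc1ccc(-c2cnc3nc(N)nc(N4CCN(c5ccc(C)cc5)CC4)c3n2)cc1OC` gives 300 nM and compound 2 `COc1ccc(-c2cnc3nc(N)nc(N4CCN(c5cc(Cl)cc(Cl)c5)CC4)c3n2)cc1OC` gives 3400 nM; the steps of an 11-fold higher number from compound 1 to compound 2 (1.05 log units; beyond the scatter), an 88-fold lower number from compound 1 to compound 3 (1.95 log units; beyond the scatter) and a 1000-fold lower number from compound 2 to compound 3 (3.00 log units; beyond the scatter) all turn on the group carried by the amine nitrogen in the ring. Compound 4 `COc1ccc(-c2cnc3nc(N)nc(N4CCN(C(=O)Nc5ccc(C#N)cc5)CC4)c3n2)cc1OC` keeps the phenylcarbamoyl of compound 3 and differs only by cyano in place of hydrogen on an aromatic carbon, on an aromatic carbon para to a large group. Among the compounds with values here, no measured step touches that aromatic ring, so the three steps speak only to the carbamoyl itself, which compound 4 retains. A step within the scatter, without a direction, is therefore expected in this assay. For compound 4 the expected value is 4 nM, with a range from 1.5 nM to 12 nM. The expected step is a 1.2-fold higher number from compound 3 to compound 4 (0.07 log units; within the scatter).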

Compound 4, half-maximal inhibitory concentration: 74 nM
The estimate for compound 4 lay 19-fold (1.27 log units) below the measured number; measured number above the stated range.
By their numbers in this assay, from the lowest: compound 3; then compound 4; then compound 1; then compound 2.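

In this assay the aromatic ring of the phenylcarbamoyl is not a silent position: cyano in place of hydrogen, para to a large group, gives a 22-fold higher number from compound 3 to compound 4 (1.34 log units; beyond the scatter) as a large loss of inhibition. The (4-cyanophenyl)carbamoyl still keeps an edge over the aryl groups, with a 46-fold lower number from compound 2 to compound 4 (1.66 log units; beyond the scatter) as a large step but a 4.1-fold lower number from compound 1 to compound 4 (0.61 log units; beyond the scatter) as only a modest one. No measurement on hand accounts for the cyano effect. From the compounds shown here alone, whether a methoxy, a fluorine or an amine at the same carbon would cost as much remains open. So does the outcome of cyano at the other carbons of that ring.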